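Sulfonyl aryl variation on a shared sulfonamide core

This account rests on a few compounds, and the source may have more. Where it says the series, first, only, none or still open, it means among the compounds named here.

Compound 3 `COc1cc(C)c(S(=O)(=O)N(C)CCOCC(=O)N(C)Cc2ccc(C3=NCCN3)cc2)c(C)c1` carries a 4-methoxy-2,6-dimethylphenyl group on the sulfonyl sulfur and gives 8.2 in a functional assay for antagonist activity at B1 bradykinin receptor (Mus musculus), using Schild analysis, with a stated time of 30 min (on this read-out lower numbers stand for lower potency and higher numbers for higher potency (the scale is a negative logarithm)), the highest of the three numbers in hand. Compound 1 `COc1ccc(S(=O)(=O)N(C)CCOCC(=O)N(C)Cc2ccc(C3=NCCN3)cc2)c(C)c1`, the same core with hydrogen in place of one methyl on the aromatic carbon, gives 6.9 in this assay. Compound 2 `CN(Cc1ccc(C2=NCCN2)cc1)C(=O)COCCN(C)S(=O)(=O)c1ccccc1C#N`, with 2-cyanophenyl on the sulfonyl sulfur, gives 6 in this assay. The steps are a number 1.30 log units higher from compound 1 to compound 3 (beyond the scatter), a number 0.90 log units lower from compound 1 to compound 2 (beyond the scatter) and a number 2.20 log units higher from compound 2 to compound 3 (beyond the scatter), all beyond the scatter.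

Compound 4 `CN(Cc1ccc(C2=NCCN2)cc1)C(=O)COCCN(C)S(=O)(=O)c1c(F)cccc1F` is the next variation: 2,6-difluorophenyl in place of 4-methoxy-2,6-dimethylphenyl on a sulfonyl sulfur. The change strips away the methoxy and both methyls of compound 3. Going by the values given here, the steps that bear on it both point the same way: removing a single methyl cost a number 1.30 log units higher from compound 1 to compound 3 (beyond the scatter) in reverse, and the full aryl swap to 2-cyanophenyl was worth a number 2.20 log units higher from compound 2 to compound 3 (beyond the scatter) in reverse. A large drop in this assay is therefore expected, smaller than the latter since the entering ring keeps two substituents flanking the sulfonyl attachment. The expected step is a number 1.40 log units lower from compound 3 to compound 4 (beyond the scatter). Compound 4 is estimated at 6.8, within a range of 5.8 to 7.8.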

Compound 4, negative logarithm of the antagonist equilibrium constant: 6
For compound 4 the middle estimate is 0.80 log units above the measured one; the range from low to high includes it.
By their numbers in this assay, from the lowest: compounds 2 and 4 (each within the scatter of the next); then compound 1; then compound 3.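

In this assay, the step to 2,6-difluorophenyl on the sulfonyl sulfur is a number 2.20 log units lower from compound 3 to compound 4 (beyond the scatter), so among these two rings, the shared substitution pattern alone does not preserve the high value; it holds with the methyls and methoxy of compound 3, not with the fluorines of compound 4. Two differently substituted rings now land together, with no change at the digits printed from compound 2 to compound 4 (within the scatter), while the single-methyl ring of compound 1 stands apart, with a number 0.90 log units lower from compound 1 to compound 4 (beyond the scatter). Nothing at hand gives a measured reason for these differences.

Still open, on these data alone, is how much of the value of compound 3 rests on the methoxy and how much on the two methyls. A 2,6-dimethylphenyl group without the methoxy, or a 4-methoxy-2,6-difluorophenyl group, would separate these contributions.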